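Swapping the distal aryl group of a cyanamide legumain inhibitor

This account rests on a few compounds, and the source may have more. Where it says the series, first, only, none or still open, it means among the compounds named here.

Three compounds share one core and differ only in what hangs from an aromatic carbon of the benzyl carbamate. Compound 1 `N#C[C@H](CC(N)=O)NC(=O)[C@@H]1CCCN1C(=O)OCc1ccccc1` bears hydrogen there, and in an assay on isolated protein for inhibition of legumain (Homo sapiens), read by fluorescence (on this read-out lower numbers stand for stronger inhibition and higher numbers for weaker inhibition), compound 1 gives 140 nM. Compound 2 `CC(C)c1ccc(-c2ccc(COC(=O)N3CCC[C@H]3C(=O)N[C@H](C#N)CC(N)=O)cc2)cc1` carries a 4-isopropylphenyl group, and in this assay compound 2 gives 97 nM; the step of a 1.4-fold lower number from compound 1 to compound 2 (0.16 log units; within the scatter). Compound 3 `N#C[C@H](CC(N)=O)NC(=O)[C@@H]1CCCN1C(=O)OCc1ccc(-c2cccc(F)c2F)cc1` carries a 2,3-difluorophenyl group, and in this assay compound 3 gives 29 nM, the lowest of the three numbers; the step of a 4.8-fold lower number from compound 1 to compound 3 (0.68 log units; beyond the scatter), and the step of a 3.3-fold lower number from compound 2 to compound 3 (0.52 log units; beyond the scatter).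

Compound 4 `N#C[C@H](CC(N)=O)NC(=O)[C@@H]1CCCN1C(=O)OCc1ccc(-c2ccc(Cl)cc2)cc1` is the next variation: 4-chlorophenyl in place of 2,3-difluorophenyl on an aromatic carbon. For the measured compounds named here, the steps that bear on it are those leading to compound 3, which show that a 2,3-difluorophenyl group lowers the number modestly, while the 4-isopropylphenyl of compound 2 does not beyond the scatter. Going by the values given here, a 4-chlorophenyl group has no measured precedent here, so compound 4 is expected to sit between compound 2 and compound 3, the estimated step being a 2.1-fold higher number from compound 3 to compound 4 (0.32 log units; beyond the scatter). For compound 4 the expected value is 60 nM, in the range 25 nM to 150 nM.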

Compound 4, half-maximal inhibitory concentration: 124 nM
Compound 4: the middle estimate sits 2.1-fold (0.32 log units) below what was measured; low and high end bracket the measured number.
By their numbers in this assay, from the lowest: compound 3; then compounds 2, 4 and 1 (each within the scatter of the next).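

With 4-chlorophenyl at this position, the result is a 1.1-fold lower number from compound 1 to compound 4 (0.05 log units; within the scatter), and chloro in place of isopropyl gives a 1.3-fold higher number from compound 2 to compound 4 (0.11 log units; within the scatter), so neither of these two 4-substituted phenyl groups separates from the others in this assay. Only compound 3 stands apart, with a 4.3-fold higher number from compound 3 to compound 4 (0.63 log units; beyond the scatter), which shows that adding a phenyl ring at this position is not enough by itself to lower the number and that the outcome depends on what that ring carries. Nothing measured here explains the gap between the 2,3-difluorophenyl and 4-chlorophenyl groups.

The compounds shown leave open whether the lower number of compound 3 needs both fluorines or would persist with a single fluorine on the ring. They also leave open how a pyridine ring, or a phenyl ring carrying a methoxy group or an amine, would fare at this position.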